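A few compounds are considered here, and "the series" means these few. Any claim that something is new, unique, unknown or untested is made for them only; others in the source may bear on it.

Measured so far in a functional assay on NCI-H1975 cells (Homo sapiens) for antiproliferative activity, with a stated time of 72 h; a higher number here means a weaker inhibitor of growth, a lower number a stronger inhibitor of growth:
Compound 1 `COc1cc(CN(C)C(=O)c2cc(Cl)c(O)cc2O)c(Cl)c(OC)c1OC`: 33800 nM
Compound 2 `CCNC(=O)c1ccc(CN(C)C(=O)c2cc(Cl)c(O)cc2O)cc1`: 21700 nM
Compound 3 `Cc1ccc(CN(C)C(=O)c2cc(Cl)c(O)cc2O)cc1`: 34300 nM

All three compounds carry chloro on the shared core and differ elsewhere. Compound 2, at 21700 nM, stands level with the other two, since all three numbers lie within the scatter of one another. Among the measured compounds shown here, the one measured single-place step, a 1.6-fold higher number from compound 2 to compound 3 (0.20 log units; within the scatter), puts methyl in place of ethylcarbamoyl and stays within the scatter.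

Compound 4 `CCNC(=O)c1ccc(CN(C)C(=O)c2cc(C(C)C)c(O)cc2O)cc1` alters compound 2 in one place: isopropyl in place of chloro on an aromatic carbon, ortho to a hydroxy group and para to a hydroxy group (isopropyl in place of chloro on an aromatic carbon). For the measured compounds named here, no measured step touches that place, so the data give no direct guide to its size. The expectation in this assay is therefore loose: a modest move to a lower number, with no real change also possible. The expected size is an estimated 2.2-fold lower number from compound 2 to compound 4 (0.34 log units; beyond the scatter). For compound 4 the estimated value is 10000 nM, with an expected range from 2000 nM to 35000 nM.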

Compound 4, concentration for 50% growth inhibition: 460 nM
Beside the measured number, compound 4's estimate is 22-fold (1.34 log units) above it, and the stated range ends above it.
By their numbers in this assay, from the lowest: compound 4; then compounds 2, 1 and 3 (each within the scatter of the next).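

In this assay, the place on the shared core that holds chloro proves highly sensitive: isopropyl in place of chloro gives a 47-fold lower number from compound 2 to compound 4 (1.67 log units; beyond the scatter) and brings the first clear separation among these compounds. Among the compounds shown here, the only earlier step, a 1.6-fold higher number from compound 2 to compound 3 (0.20 log units; within the scatter), lies elsewhere on the molecule and stays within the scatter. The change adds carbon atoms in place of a chlorine atom without altering the count of hydrogen-bond donors, hydrogen-bond acceptors or net charge, and no measurement here explains why the number falls so far.

A single replacement cannot show whether this gain is specific to isopropyl or would also appear with ethyl, tert-butyl or cyclopropyl at this place. It also leaves open whether isopropyl would have a similar effect in compound 3, which has methyl in place of ethylcarbamoyl.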